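The source may hold more compounds than are shown below. What is called first, only, known or untested is meant among the compounds shown, and "the series" means these compounds.

Compound 1 `COc1ccc(C(=O)/C=C/c2nc3ccccc3cc2-c2ccc(OC)cc2)cc1`: 6420 nM
Compound 2 `COc1ccc(-c2cc3ccccc3nc2/C=C/C(=O)c2ccc(OC)cc2OC)cc1`: 3770 nM
Compound 3 `COc1ccc(-c2cc3ccccc3nc2/C=C/C(=O)c2ccc(Br)s2)cc1`: 710 nM

In a functional assay on NCI-H1299 cells (Homo sapiens) for antiproliferative activity, read by XTT assay, with a stated time of 72 h (a lower number here means a stronger inhibitor, a higher number a weaker inhibitor), compound 1 has the highest of the three numbers; the nearest step away from it is a 1.7-fold lower number from compound 1 to compound 2 (0.23 log units; within the scatter), the furthest is a 9.0-fold lower number from compound 1 to compound 3 (0.96 log units; beyond the scatter). Compound 4 `COc1ccc(-c2cc3ccccc3nc2/C=C/C(=O)c2cnc(N)nc2C)cc1` differs from compound 1 in one place: 2-amino-4-methylpyrimidin-5-yl in place of 4-methoxyphenyl on a carbonyl carbon. The step that bears on this is the earlier replacement of the 4-methoxyphenyl on the carbonyl carbon, a 9.0-fold lower number from compound 1 to compound 3 (0.96 log units; beyond the scatter), and a 5.3-fold lower number from compound 2 to compound 3 (0.73 log units; beyond the scatter) points the same way, so a change at this position has so far lowered the number modestly. Within the data shown here, no measured step shows the 2-amino-4-methylpyrimidin-5-yl group itself, so the expectation is loose. Compound 4 is expected at 3000 nM, between 800 nM and 12000 nM, estimated as a 2.1-fold lower number from compound 1 to compound 4 (0.33 log units; beyond the scatter).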

Compound 4, half-maximal inhibitory concentration: > 10000 nM
Compound 4 was reported as a limit (the forecaster's own chance of this, stated with the estimate: 5%); middle value at least 3.3-fold (0.52 log units) away from the limit.
By their numbers in this assay, from the lowest: compound 3; then compounds 2 and 1 (each within the scatter of the next). At a limit, above all of these: compound 4.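

Compound 4 stands at a limit in this assay, not at a number: the limit of > 10000 nM in this assay, at which 1 of the 4 values shown sits. The earlier replacements on this carbonyl carbon lowered the number, but this one runs the other way, with an at least 14-fold higher number from compound 3 to compound 4 (1.14 log units; beyond the scatter) and an at least 2.6-fold higher number from compound 2 to compound 4 (0.42 log units; beyond the scatter) as the steps that can be read clearly. Against compound 1 the result is only a floor, an at least 1.5-fold higher number from compound 1 to compound 4 (0.19 log units; that floor lies within the scatter), so no loss relative to that compound is established.

The compounds shown leave open which part of the 2-amino-4-methylpyrimidin-5-yl group matters, the amine or the methyl. They also leave open whether a thiophene carrying chlorine instead of bromine would match compound 3.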